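Aryl variation on the shared core: 2-fluorophenyl to 4-bromophenyl

The source may report more compounds than this note shows. Statements on the series, on what has been measured and on what is new or still open speak of the compounds shown alone.

Measured compounds:
compound 1 `CCOC(=O)C12C(=O)OCC=C1COC2c1ccccc1F`, 22100 nM
compound 2 `CCOC(=O)C12C(=O)OCC=C1COC2c1ccc(Cl)cc1`, 118000 nM
compound 3 `CCOC(=O)C12C(=O)OCC=C1COC2c1ccc(Cl)c(Cl)c1`, 72400 nM

In a functional assay on HeLa cells (Homo sapiens) for cytotoxicity, read by MTT assay (on this read-out lower numbers stand for stronger inhibition and higher numbers for weaker inhibition), compound 1 gives 22100 nM, the lowest of the three numbers; compound 3 gives 72400 nM and compound 2 gives 118000 nM. Both gaps from compound 1 lie beyond the scatter.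

Compound 4 `CCOC(=O)C12C(=O)OCC=C1COC2c1ccc(Br)cc1` is not yet measured. Its change from compound 1 is 4-bromophenyl in place of 2-fluorophenyl on a saturated ring carbon. Within the data shown here, the only measured step that bears on it is the one that swaps the same 2-fluorophenyl for a 4-halophenyl: a 5.3-fold higher number from compound 1 to compound 2 (0.73 log units; beyond the scatter). The further step a 1.6-fold lower number from compound 2 to compound 3 (0.21 log units; within the scatter) adds a second chloro and stays within the scatter, so it says little about the aryl swap itself. Among the measured compounds shown here, with a bromine in the place of the chlorine, a step of similar kind and direction is expected, namely a higher number in this assay, though its exact size is uncertain because only the step from compound 1 to compound 2 a 5.3-fold higher number from compound 1 to compound 2 (0.73 log units; beyond the scatter) is available as a guide. For compound 4 the expected step is a 4.1-fold higher number from compound 1 to compound 4 (0.61 log units; beyond the scatter), and the estimate is 90000 nM with a range from 35000 nM to 250000 nM.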

Compound 4, half-maximal inhibitory concentration: 48700 nM
Compound 4: middle estimate off by 1.8-fold (0.27 log units), on the high side, within the range that was stated.
By their numbers in this assay, from the lowest: compound 1; then compounds 4, 3 and 2 (each within the scatter of the next, the first and the last beyond it).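

In this assay, 4-bromophenyl in place of 2-fluorophenyl on the saturated ring carbon gives a 2.2-fold higher number from compound 1 to compound 4 (0.34 log units; beyond the scatter), so a higher number now follows this swap with a second 4-halophenyl group and not with 4-chlorophenyl alone, and compound 1 remains the lowest of the four. The halogen itself also counts at this aryl group: bromo in place of chloro on an aromatic carbon gives a 2.4-fold lower number from compound 2 to compound 4 (0.38 log units; beyond the scatter), so 4-bromophenyl and 4-chlorophenyl cannot be treated as interchangeable in this series. No supporting data are available to explain either step.

The compounds shown include no 4-fluorophenyl or 2-bromophenyl group, so the identity of the halogen and its place on the aryl ring remain unseparated, and it stays open whether the lower number of compound 1 belongs to the fluorine, to its place, or to both. Also open, going by these compounds, is how a non-halogen substituent on the aryl ring, such as an amine, a methoxy group or a carboxylic acid, would read in this assay, and whether any other group at the ethoxycarbonyl position would shift these numbers.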